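The source may report more compounds than this note shows. Statements on the series, on what has been measured and on what is new or still open speak of the compounds shown alone.

In an ADME assay on microsomes from liver (Rattus norvegicus) for metabolic stability (a lower number here means that the compound disappears faster, a higher number that the compound lasts longer), compound 3 `Cc1nc(C(c2ccc(-c3ccc4cccc(F)c4c3)[nH]c2=O)C(C)C)[nH]c1C` gives 0.0733 h, the lowest number in this small set. Compound 2 `CCC(CC)(c1nnc[nH]1)c1ccc(-c2ccc3cccc(F)c3c2)[nH]c1=O` gives 0.925 h, well beyond the scatter from compound 3, although the two differ in more than one place. Compound 1 `CCn1ncc2c(F)cc(-c3ccc(C(CC)(CC)c4nnc[nH]4)c(=O)[nH]3)cc21` is reported only as a limit, > 3 h. Compound 4 `CC(C)C(Cc1nnn[nH]1)c1ccc(-c2ccc3cccc(F)c3c2)[nH]c1=O` has (1H-tetrazol-5-yl)methyl in place of 4,5-dimethyl-1H-imidazol-2-yl on a saturated chain carbon bound to an aromatic carbon and a saturated chain carbon. Going by the values given here, no measured pair isolates this change, so the expectation is tentative. Compound 2, which also lacks the 4,5-dimethyl-1H-imidazol-2-yl group, stands at 0.925 h, and a rise beyond the scatter in this assay is expected. The expected size of the rise is a 12-fold higher number from compound 3 to compound 4 (1.09 log units; beyond the scatter). The estimate for compound 4 is 0.9 h, with an expected range of 0.2 h to 3 h.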

Compound 4, half-life: 2.08 h
Compound 4: middle estimate off by 2.3-fold (0.36 log units), on the low side, and the stated range covers the measured number.
By their numbers in this assay, from the lowest: compound 3; then compound 2; then compound 4. At a limit, above all of these: compound 1.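

Going by these compounds alone, on a saturated chain carbon bound to an aromatic carbon and a saturated chain carbon, this is the first single change that can be read in this assay: (1H-tetrazol-5-yl)methyl in place of 4,5-dimethyl-1H-imidazol-2-yl gives a 28-fold higher number from compound 3 to compound 4 (1.45 log units; beyond the scatter). The position is therefore sensitive to this exchange, though one pair gives no trend. Compound 1 is reported as a limit, not a number: the limit of > 3 h in this assay, at which 1 of the 4 values shown sits.

From the compounds shown here alone, whether the tetrazole ring or its methyl link carries the step remains open. A carboxylic acid or an amine at this place would test how far the step extends beyond this pair.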